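Swapping a Chloro for an Ethoxy on a Nucleoside Core

The compounds below may be only part of what the source reports. "The series", "measured", "known", "first", "only" and "open" are said of these compounds alone.

Compound 1 `OC[C@@H](O)[C@H]1O[C@@H](n2cnc3c(Cl)nc(Cl)nc32)[C@H](O)[C@@H]1O` carries two chloro groups on its core, joined to a sugar. In a functional assay on HL-60 cells (Homo sapiens), read by colorimetric assay, with a stated time of 24 h (a higher number here means a weaker inhibitor, a lower number a stronger inhibitor), compound 1 gives > 100000 nM, which is a limit of the assay rather than a measured number. Compound 2 `OC[C@@H](O)[C@H]1O[C@@H](n2cnc3c(-c4ccccc4)ncnc32)[C@H](O)[C@@H]1O` keeps the same sugar and has a phenyl group on its core. In this assay compound 2 gives > 100000 nM, again a limit and not a number. Going by the values given here, both results sit at the limit of > 100000 nM in this assay, at which 2 of the 2 values shown sit, so compound 1 cannot be placed above or below compound 2: within the reach of the measurement neither shows any inhibition, and no step between them can be sized.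

Compound 3 `CCOc1nc(Cl)nc2c1ncn2[C@@H]1O[C@H]([C@H](O)CO)[C@@H](O)[C@H]1O` arises from compound 1 by one change: ethoxy in place of chloro on an aromatic carbon. Among the compounds with values here, with no measured step to lean on, the expectation for this assay is that this change gives no step beyond the scatter, so the expected step of a number no higher from compound 1 to compound 3 (the limit leaves the size open) is essentially flat. Compound 3 is therefore estimated at 100000 nM, within a range from 30000 nM to 300000 nM, and will most probably be reported only as a limit once more.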

Compound 3, half-maximal inhibitory concentration: > 100000 nM
Compound 3 was reported as a limit; the forecaster's own chance of this, stated with the estimate: 80%; the middle value lies on the limit itself.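

In this assay compound 3 gives a limit and not a number, as compound 1 does, so the swap of chloro for ethoxy between compound 1 and compound 3 has no readable size: the limit of > 100000 nM in this assay, at which 3 of the 3 values shown sit. The compounds shown leave open whether any change to the shared core brings inhibition that can be measured.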